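The compounds below may be only part of what the source reports. "The series", "measured", "known", "first", "only" and "open" are said of these compounds alone.

Measured compounds:
- compound 1 `CC1CCN(c2c(S(=O)(=O)c3cc(F)cc(F)c3)cnc3cc(Cl)ccc23)CC1`, 195 nM in an assay on isolated protein for displacement of a labelled ligand from metabotropic glutamate receptor 5 (Homo sapiens), with a stated time of 60 min; on this read-out lower numbers stand for stronger inhibition and higher numbers for weaker inhibition
- compound 3 `CC1CCN(c2c(S(=O)(=O)c3ccc(Cl)c(Cl)c3)cnc3ccc(F)cc23)CC1`, 68.2 nM in this assay
- compound 2 `CN1CCN(c2c(S(=O)(=O)c3ccccc3)cnc3ccccc23)CC1`, "not determined" (no result reported) in this assay

Compound 2 carries a 4-methylpiperazin-1-yl group and no halogen on either aryl ring, and for compound 2 no single number exists in this assay, so compound 2 cannot be placed against compound 1 or compound 3 on the numbers shown. The two measured compounds, compound 1 and compound 3, both carry a 4-methylpiperidine group and halogens on both aryl parts, and their values sit fairly close to one another.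

Compound 4 `O=S(=O)(c1ccccc1)c1cnc2ccccc2c1N1CCCCC1` is the next compound in this line. The change from compound 2 to compound 4 is piperidin-1-yl in place of 4-methylpiperazin-1-yl on an aromatic carbon. Since compound 2 has no value, no size or direction of the step can be anchored; the change is simply the loss of one ring nitrogen and its methyl from the saturated ring.

Compound 4 shares no halogen with compound 1 or compound 3, so its value is expected to lie somewhat weaker than those two; compound 4 is estimated at 450 nM, within a range of 120 nM to 2000 nM.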

Compound 4, inhibition constant: 307 nM
Compound 4: the middle estimate sits 1.5-fold (0.17 log units) above what was measured; the measured number falls inside the stated range.
By their numbers in this assay, from the lowest: compound 3; then compounds 1 and 4 (each within the scatter of the next).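

No step can be read from compound 2 to compound 4, since compound 2 has no single number in this assay and compound 4 at 307 nM has nothing to be set against. No measured evidence bears on this result.
The compounds shown leave open how piperidin-1-yl compares with 4-methylpiperazin-1-yl on the shared core.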